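Urea aryl swap on a pyrazole series: compound 1 to compound 4

A few compounds are considered here, and "the series" means these few. Any claim that something is new, unique, unknown or untested is made for them only; others in the source may bear on it.

Compound 1 `COc1cc(Cl)cc(-c2nn(-c3cccc(NC(=O)Nc4cccc(C(F)(F)F)c4)c3)cc2-c2ccncc2)c1` gives 77% in a functional assay on SNB-19 cells (Homo sapiens) for inhibition, read by sulforhodamine B assay, with a stated time of 48 h, tested at 1 uM (on this read-out lower numbers stand for a stronger effect and higher numbers for a weaker effect at the one concentration tested), the lowest of the three numbers shown. Compound 3 `O=C(Nc1cccc(-n2cc(-c3ccncc3)c(-c3cc(O)cc(Cl)c3)n2)c1)Nc1ccc(Cl)c(Cl)c1` gives 90%, and compound 2 `COc1cc(Cl)cc(-c2nn(-c3cccc(NC(=O)c4cccc(C(F)(F)F)c4)c3)cc2-c2ccncc2)c1` gives 100%. Among the measured compounds shown here, the only single step measured, a number 23 percentage points higher from compound 1 to compound 2 (beyond the scatter), concerns the carbonyl side rather than the aryl group and so bears little on the present change. Compound 4 `COc1cc(Cl)cc(-c2nn(-c3cccc(NC(=O)Nc4ccc(Cl)c(Cl)c4)c3)cc2-c2ccncc2)c1` differs from compound 1 by 3,4-dichlorophenyl in place of 3-(trifluoromethyl)phenyl on an amide-type nitrogen. Compound 3 carries the same 3,4-dichlorophenyl urea on a different core and sits higher than compound 1, so a small rise is expected here, a number 8 percentage points higher from compound 1 to compound 4 (within the scatter), though it may stay within the scatter. Compound 4 is therefore estimated at 85%, between 70% and 100%.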

Compound 4, a percentage reported as activity, at one concentration (the size of the read-out at that concentration, not a potency): 89%
The estimate for compound 4 lay 4 percentage points below the measured number; the measured number falls inside the stated range.
By their numbers in this assay, from the lowest: compound 1; then compounds 4, 3 and 2 (each within the scatter of the next, the first and the last beyond it).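

Replacing 3-(trifluoromethyl)phenyl with 3,4-dichlorophenyl on the amide-type nitrogen weakens the effect, giving a number 12 percentage points higher from compound 1 to compound 4 (beyond the scatter). With 3,4-dichlorophenyl in place, methyl in place of hydrogen on the oxygen gives a number 1 percentage points lower from compound 3 to compound 4 (within the scatter), while (3,4-dichlorophenyl)amino in place of 3-(trifluoromethyl)phenyl on the carbonyl carbon gives a number 11 percentage points lower from compound 2 to compound 4 (beyond the scatter). No measurement at hand accounts for these steps. The compounds shown leave open how an aryl group carrying an amine or a carboxylic acid would behave on this nitrogen, and whether a single chlorine would read like either group.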